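This account rests on a few compounds, and the source may have more. Where it says the series, first, only, none or still open, it means among the compounds named here.

Of the compounds shown here, two of one shared core have been tested in an assay on isolated protein for inhibition of Aromatase (Homo sapiens), read by fluorescence, using NADPH, with a stated time of 30 min, tested at 50 uM; on this read-out lower numbers stand for less inhibition and higher numbers for more inhibition at the one concentration tested (going by the name of the read-out). Compound 1, with structure `N#Cc1ccc2[nH]c(-c3ccccc3)cc2c1`, carries a cyano group on its core, and in this assay compound 1 gives 82.3%. Compound 2, with structure `COc1cc(OC)cc(-c2cc3ccccc3[nH]2)c1`, carries two methoxy groups on a separate phenyl ring instead, and in this assay compound 2 gives 9.18%. Compound 1 therefore stands highest of the two numbers, and the gap between compound 1 and compound 2 lies well beyond the usual scatter of repeated measurements.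

The next compound, compound 3 with structure `Nc1ccc2[nH]c(-c3ccccc3)cc2c1`, has not yet been tested. It differs from compound 1 in one place: amino in place of cyano on an aromatic carbon. Going by the values given here, no step between two measured compounds of this kind is available, so the size of the change has to be guessed from the two values alone. A loss of inhibition is expected, with the step of a number 37.3 percentage points lower from compound 1 to compound 3 (beyond the scatter) taken as the best guess, since compound 1 with its cyano group gives 82.3% and nothing else is known. For compound 3 the estimated inhibition in this assay is 45%, with a likely range from 15% to 75%.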

Compound 3, a percentage reported as inhibition, at one concentration (the size of the read-out at that concentration, not a potency): 41.4%
Compound 3: the middle estimate sits 3.6 percentage points above what was measured, and the stated range covers the measured number.
By their numbers in this assay, from the lowest: compound 2; then compound 3; then compound 1.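

Going by these compounds alone, this is the first direct reading in this assay of what the group on this aromatic carbon contributes, with the rest of the structure held the same: the step is a number 40.9 percentage points lower from compound 1 to compound 3 (beyond the scatter). The position is therefore not indifferent to what it carries, yet compound 3 still gives 41.4%, so inhibition at the tested concentration does not disappear when the cyano group is replaced by amino. Nothing available explains the difference between the two groups, and the swap changes several things at once, including the triple bond that leaves and the hydrogen-bond donor that enters, so this single step cannot show which of them matters.

Still open, on these data alone, is how other groups on this same carbon would read, such as a hydroxyl, a carboxylic acid or a methylamino group, and so whether cyano and amino belong to a wider trend. Also open, as far as these compounds go, is whether the step keeps its size when the separate phenyl ring carries substituents, such as the two methoxy groups seen in compound 2.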